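The compounds below may be only part of what the source reports. "The series", "measured", "known", "first", "only" and "open" are said of these compounds alone.

The series shares one core and varies the aryl group on the carbon with a double bond to nitrogen. In a functional assay on NCI-H460 cells (Homo sapiens) for cytotoxicity, read by MTT assay, with a stated time of 72 h (on this read-out lower numbers stand for stronger inhibition and higher numbers for weaker inhibition), compound 1 `CN(C)CCn1cnnc1-c1cc(Oc2ccc(NC(=O)N/N=C/c3cc(C(C)(C)C)cc(C(C)(C)C)c3O)cc2F)ccn1` gives 590 nM, while compound 2 `Cn1ncnc1-c1cc(Oc2ccc(NC(=O)N/N=C/c3ccccc3)cc2F)ccn1` gives 52200 nM and compound 3 `CN(C)CCn1cnnc1-c1cc(Oc2ccc(NC(=O)N/N=C/c3ccc(F)cc3F)cc2F)ccn1` gives 1930 nM. On these numbers compound 3 stands second highest of the three, with compound 1 below it and compound 2 well above it, both gaps beyond the usual scatter.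

Compound 4 `COc1ccc(/C=N/NC(=O)Nc2ccc(Oc3ccnc(-c4nncn4CCN(C)C)c3)c(F)c2)cc1O` differs from compound 3 in one place: 3-hydroxy-4-methoxyphenyl in place of 2,4-difluorophenyl on a carbon with a double bond to nitrogen. For the measured compounds named here, no measured pair shows the effect of such a swap, so the expected step from compound 3 to compound 4 is taken to be small, a slight move towards a lower number that may not exceed the scatter, a 1.4-fold lower number from compound 3 to compound 4 (0.14 log units; within the scatter). In this assay compound 4 is expected to give about 1400 nM, with a likely range from 450 nM to 4500 nM.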

Compound 4, half-maximal inhibitory concentration: 620 nM
Compound 4: the middle estimate sits 2.3-fold (0.35 log units) above what was measured, within the range that was stated.
By their numbers in this assay, from the lowest: compounds 1 and 4 (each within the scatter of the next); then compound 3; then compound 2.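

In this assay, for the compounds shown here, the swap of 2,4-difluorophenyl for 3-hydroxy-4-methoxyphenyl gives a 3.1-fold lower number from compound 3 to compound 4 (0.49 log units; beyond the scatter), the first reading of this position with the rest of the molecule held fixed. Going by these compounds alone, no two earlier compounds differed in one place only, so they could not isolate this group. Nothing measured on these compounds accounts for the step.

The hydroxy and methoxy groups enter together, leaving open which of them carries the change. Also open, from the compounds shown here alone, is how an aryl group bearing an amine or a carboxylic acid would read here.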